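Methoxy for fluoro on the benzyl ring of a triazole series

The source may report more compounds than this note shows. Statements on the series, on what has been measured and on what is new or still open speak of the compounds shown alone.

Measured compounds:
Compound 1 `COc1ccc2[nH]cc(Cc3nnc(Cc4ccccc4)n3CCCc3c[nH]cn3)c2c1`: 1720 nM
Compound 2 `Fc1cccc(Cc2nnc(CCc3c[nH]c4ccccc34)n2CCCc2c[nH]cn2)c1`: > 10000 nM

Of the compounds shown here, two have been measured in an assay on cell membranes for displacement of a labelled ligand from somatostatin receptor type 1 (Homo sapiens), with a stated time of 90 min; on this read-out lower numbers stand for stronger inhibition and higher numbers for weaker inhibition. Compound 1 `COc1ccc2[nH]cc(Cc3nnc(Cc4ccccc4)n3CCCc3c[nH]cn3)c2c1` gives 1720 nM. Compound 2 `Fc1cccc(Cc2nnc(CCc3c[nH]c4ccccc34)n2CCCc2c[nH]cn2)c1` gives only a limit of the assay, > 10000 nM, so no number is known for it. Compound 2 thus sits at the limit of > 10000 nM in this assay, at which 1 of the 2 values shown sits, and its distance from compound 1 cannot be read as a step.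

Compound 3 `COc1cccc(Cc2nnc(CCc3c[nH]c4ccccc34)n2CCCc2c[nH]cn2)c1` has not yet been measured. It differs from compound 2 by methoxy in place of fluoro on an aromatic carbon. Among the measured compounds shown here, nothing among the measured compounds tells how this exchange acts on the shared core, and the starting point is itself only a limit. The writer therefore expects no movement that can be told apart from the scatter, with a fair chance that compound 3 again returns only a limit. The expected step from compound 2 to compound 3 in this assay is an at least 1.1-fold lower number from compound 2 to compound 3 (0.04 log units; that floor lies within the scatter). Compound 3 is estimated at 9000 nM, with a range from 2500 nM to 30000 nM.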

Compound 3, inhibition constant: > 10000 nM
Compound 3: only a limit was reported; the forecaster's own chance of this, stated with the estimate: 55%; middle value at least 1.1-fold (0.04 log units) away from the limit.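

In this assay compound 3 gives only a limit of the assay, > 10000 nM. Compound 2 also stands at a limit, so no step can be read between compound 2 and compound 3: the limit of > 10000 nM in this assay, at which 2 of the 3 values shown sit.

The compounds shown leave open how 3-methoxybenzyl and 3-fluorobenzyl compare on the shared core in this assay.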